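This account rests on a few compounds, and the source may have more. Where it says the series, first, only, none or still open, it means among the compounds named here.

Measured compounds:

Compound 1, `CCS(=O)(=O)Nc1cccc2c1CCCC2c1c[nH]cn1`, in an assay on isolated protein for binding affinity to Alpha-1D adrenergic receptor (Rattus norvegicus), read by radioligand binding (on this read-out lower numbers stand for stronger inhibition and higher numbers for weaker inhibition), gives 1070 nM.
Compound 2, `CCS(=O)(=O)Nc1cccc(NC2=NCCN2)c1`, in this assay gives 355 nM.
Compound 3, `CCS(=O)(=O)Nc1cccc2c1CCCC2CNC`, in this assay gives < 10000 nM, which is a limit of the assay and not a number.

Compound 3 therefore stands only at a limit; its true inhibition constant could lie anywhere on the stronger side of it. Among the three values shown it is the one sitting at the limit of < 10000 nM in this assay, at which 1 of the 3 values shown sits. Among the measured compounds shown here, the only one-place step that reaches compound 3 is the one from compound 1, a step that the limit leaves unreadable from compound 1 to compound 3, and because the value of compound 3 is a limit, the size of that step cannot be read.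

Compound 4, `CCS(=O)(=O)Nc1cccc2c1CCCC2CN`, differs from compound 3 by hydrogen in place of methyl on an amine nitrogen. No measured step here involves a change on an amine nitrogen, and the one step touching compound 3 is unreadable, so nothing shown gives the size or direction to expect in this assay for this change. Compound 4 is therefore estimated at 4000 nM, with a range from 600 nM to 15000 nM, the step from compound 3 to compound 4 being expected as a step that the limit leaves unreadable from compound 3 to compound 4, with a real chance that the assay again reports only a limit.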

Compound 4, inhibition constant: < 10000 nM
Compound 4: no number, only a limit (the forecaster's own chance of this, stated with the estimate: 35%); the middle value is on the limit's open side.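

In this assay compound 4 gives < 10000 nM, which is a limit of the assay and not a number. The steps reaching compound 4 from compound 1 and from compound 3 therefore cannot be read: the limit of < 10000 nM in this assay, at which 2 of the 4 values shown sit.

From the compounds shown here alone, the true values of compound 3 and compound 4 remain open, as does whether hydrogen in place of methyl on the amine nitrogen changes anything.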